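Methoxyphenyl for fluorophenyl on the amide series

This account rests on a few compounds, and the source may have more. Where it says the series, first, only, none or still open, it means among the compounds named here.

Measured compounds in an assay on HEK293 cells for activation of Kir3.1/Kir3.2 (Homo sapiens), read by thallium flux; a lower number here means that less compound is needed, a higher number that more compound is needed for the effect:
compound 1 `Cc1cc(NC(=S)Cn2nnc(-c3ccccc3)n2)n(C2CCCCC2)n1` gives 623 nM
compound 2 `Cc1cc(NC(=O)Cn2nnc(-c3cccc(F)c3)n2)n(C2CCCCC2)n1` gives 81 nM

Compound 2 gives the lower of the two numbers; compound 1 gives the higher, and the gap lies beyond the scatter. The two structures differ in more than one place, so only the two values themselves can be set side by side. Compound 3 `COc1ccc(-c2nnn(CC(=O)Nc3cc(C)nn3C3CCCCC3)n2)cc1` carries 4-methoxyphenyl in place of 3-fluorophenyl on an aromatic carbon. Among the measured compounds shown here, no step between measured compounds is available to calibrate this change; in this assay a modest shift is expected, a 1.9-fold higher number from compound 2 to compound 3 (0.27 log units; within the scatter), leaning toward a somewhat higher number. Compound 3 is estimated at 150 nM, range 40 nM to 600 nM.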

Compound 3, half-maximal effective concentration: 175 nM
For compound 3 the middle estimate is 1.2-fold (0.07 log units) below the measured one, and the stated range covers the measured number.
By their numbers in this assay, from the lowest: compound 2; then compound 3; then compound 1.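

In this assay, among the compounds shown here, 4-methoxyphenyl in place of 3-fluorophenyl gives a 2.2-fold higher number from compound 2 to compound 3 (0.33 log units; beyond the scatter), the only single-place step, and it lies just beyond the scatter. The position thus takes this change with a modest shift, but the group and its place on the phenyl ring change together, so the step cannot separate the two. Nothing measured here bears on the reason for this step.

Still open, on these data alone, is how 3-methoxyphenyl or 4-fluorophenyl would read on the amide series. Also open, as far as these compounds go, is whether a carboxylic acid or an amine on this phenyl ring would move the number further.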